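Amide variation on the shared core: towards compound 4

This account rests on a few compounds, and the source may have more. Where it says the series, first, only, none or still open, it means among the compounds named here.

The series keeps one core and varies the group on the carbonyl carbon. In an assay on HL-60 cells for agonist activity at vitamin D3 receptor (Homo sapiens), read by microscopy, with a stated time of 96 h (on this read-out higher numbers stand for an effect only at larger amounts of compound and lower numbers for an effect already at smaller amounts), compound 1 `CCOC(=O)CN(C)C(=O)c1ccc(C(CC)(CC)c2ccc(OCC(O)C(C)(C)C)c(C)c2)n1CC` gives 210 nM, compound 2 `CCN(CC)CCNC(=O)c1ccc(C(CC)(CC)c2ccc(OCC(O)C(C)(C)C)c(C)c2)n1CC` gives 110 nM, and compound 3 `C=CCN(C)C(=O)c1ccc(C(CC)(CC)c2ccc(OCC(O)C(C)(C)C)c(C)c2)n1CC` gives 3950 nM. Compound 3 thus stands highest of the three numbers in this assay: a 19-fold higher number from compound 1 to compound 3 (1.27 log units; beyond the scatter), and a 36-fold higher number from compound 2 to compound 3 (1.56 log units; beyond the scatter), both beyond the scatter. Between compound 1 and compound 2 the step is small: a 1.9-fold lower number from compound 1 to compound 2 (0.28 log units; within the scatter).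

Compound 4 `CC[C@@H](C)[C@H](NC(=O)c1ccc(C(CC)(CC)c2ccc(OCC(O)C(C)(C)C)c(C)c2)n1CC)C(=O)O` is not yet measured. It differs from compound 3 by (1-carboxy-2-methylbutyl)amino in place of allyl(methyl)amino on a carbonyl carbon. Within the data shown here, two measured steps bear on this. The step from compound 2 to compound 3 removes an amino-type hydrogen on the amide nitrogen and was large; the step from compound 1 to compound 3 removes an ester carbonyl chain and was also large. Compound 4 reintroduces both an amide hydrogen and a carboxy group, so in this assay a step back down of a size comparable to those two is expected: a 20-fold lower number from compound 3 to compound 4 (1.30 log units; beyond the scatter). Whether the acid reaches the numbers of compound 1 or compound 2 cannot be told from the three compounds. Compound 4 is therefore estimated at 200 nM, with a range from 50 nM to 900 nM.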

Compound 4, half-maximal effective concentration: 2.3 nM
Estimate against measurement, compound 4: 87-fold (1.94 log units) above, outside the stated range (below it).
By their numbers in this assay, from the lowest: compound 4; then compounds 2 and 1 (each within the scatter of the next); then compound 3.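

In this assay the group on the carbonyl carbon turns out to set the number over a far wider span than compounds 1 to 3 suggested, with a 1700-fold lower number from compound 3 to compound 4 (3.23 log units; beyond the scatter) for (1-carboxy-2-methylbutyl)amino in place of allyl(methyl)amino. The amide hydrogen alone does not give this result: compound 2 also carries it, yet a 48-fold lower number from compound 2 to compound 4 (1.68 log units; beyond the scatter) when 1-carboxy-2-methylbutyl replaces 2-(diethylamino)ethyl on the amide-type nitrogen. An ester-bearing chain does not give it either, with a 91-fold lower number from compound 1 to compound 4 (1.96 log units; beyond the scatter) and compound 4 clear of every other member of the series. No measurement shown gives a reason for the size of these steps.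

The compounds shown do not separate the contributions of the carboxy group, the branched 2-methylbutyl chain and the two defined stereocentres, so it remains open which of them carries the result. The ethyl ester of the same chain, the opposite configuration at either stereocentre, or a shorter carboxymethylamino group on the carbonyl carbon would each bear on that question.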